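Working notes: changing the amide group of compound 2

A few compounds are considered here, and "the series" means these few. Any claim that something is new, unique, unknown or untested is made for them only; others in the source may bear on it.

In a functional assay on U-937 cells (Homo sapiens) for antiproliferative activity, read by MTT assay, with a stated time of 24 h (on this read-out higher numbers stand for weaker inhibition and lower numbers for stronger inhibition), compound 1 `CCCCc1oc2ccccc2c1C(=O)c1ccc(OCCCC(=O)N2CCOCC2)cc1` gives 21400 nM, and compound 2 `CCCCc1oc2ccccc2c1C(=O)c1ccc(OCCCC(=O)N(C)Cc2ccccc2)cc1` gives 10500 nM. Going by the values given here, compound 2 therefore holds the lower of the two numbers so far, although only two compounds have been measured.

The next compound is compound 3 `CCCCc1oc2ccccc2c1C(=O)c1ccc(OCCCC(=O)N[C@@H](C)c2ccccc2)cc1`, and the change is (1-phenylethyl)amino in place of benzyl(methyl)amino on a carbonyl carbon. In words, (1-phenylethyl)amino stands in place of benzyl(methyl)amino on a carbonyl carbon, with the same atoms joined differently.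

Among the compounds with values here, one measured step bears on this place: a 2.0-fold lower number from compound 1 to compound 2 (0.31 log units; beyond the scatter). Within the data shown here, it is modest, and it is the only guide to how much this assay responds to changes on this carbonyl carbon. Among the measured compounds shown here, no measured compound carries the amide hydrogen or a defined stereocentre, so the data set no direction for the change. A small step is expected, with no shift beyond the scatter in either direction. The expected step is a 1.1-fold lower number from compound 2 to compound 3 (0.02 log units; within the scatter). For compound 3 the estimated value is 10000 nM, with an expected range of 4500 nM to 22000 nM.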

Compound 3, half-maximal inhibitory concentration: 22400 nM
Compound 3: the middle estimate sits 2.2-fold (0.35 log units) below what was measured; the whole stated range lies below it.
By their numbers in this assay, from the lowest: compound 2; then compounds 1 and 3 (each within the scatter of the next).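

In this assay, rejoining the same atoms on this carbonyl carbon gives a 2.1-fold higher number from compound 2 to compound 3 (0.33 log units; beyond the scatter), a modest step of the same grade as the one from the morpholin-4-yl amide to the benzyl(methyl)amino amide, so this position responds to how the atoms are joined and not only to which atoms are present. The morpholin-4-yl and (1-phenylethyl)amino groups, though different in ring content, give a 1.0-fold higher number from compound 1 to compound 3 (0.02 log units; within the scatter), which leaves benzyl(methyl)amino as the only one of the three amide groups with a number beyond the scatter of the other two. Nothing in hand accounts for the step from compound 2 to compound 3.

That single change brings in one hydrogen-bond donor and one defined stereocentre together, so the share of each in the step cannot be read from these three compounds. Benzylamino, the mirror-image form of (1-phenylethyl)amino and methyl(1-phenylethyl)amino on the same carbonyl carbon would each separate these features, and the open question is which of them, if any, tracks with the number.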